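The source may hold more compounds than are shown below. What is called first, only, known or untested is meant among the compounds shown, and "the series" means these compounds.

Compound 3 `COCCn1cc(C(=O)C(=O)Nc2ccc(OC)nc2)c2cccnc21` and compound 1 `COc1ccc(NC(=O)C(=O)c2cn(C(C)C)c3ncccc23)cn1` share one core and differ in a single place: isopropyl in place of 2-methoxyethyl on an aromatic nitrogen. In a functional assay on FaDu cells (Homo sapiens) for cytotoxicity, read by MTT assay, with a stated time of 72 h (on this read-out higher numbers stand for lower toxicity in this test and lower numbers for higher toxicity in this test), compound 3 gives 27 nM, and compound 1 gives 126 nM, which is a 4.7-fold higher number from compound 3 to compound 1 (0.67 log units; beyond the scatter). Compound 2 `COCCn1cc(C(=O)C(=O)Nc2ccc(OC)nc2)c2cc(Cl)ccc21` carries a different core, and the difference between the two cores is not broken down here. In this assay compound 2 gives only a limit, > 10000 nM, and this is the limit of > 10000 nM in this assay, at which 1 of the 3 values shown sits. Compound 4 `COc1ccc(NC(=O)C(=O)c2cn(C(C)C)c3ccc(Cl)cc23)cn1` is not yet measured and stands to compound 2 as compound 1 stands to compound 3, the same change: isopropyl in place of 2-methoxyethyl on an aromatic nitrogen. The earlier step of a 4.7-fold higher number from compound 3 to compound 1 (0.67 log units; beyond the scatter) raised the number, and a movement of the same kind is expected here. Compound 4 is therefore expected to give 30000 nM in this assay, most likely reported again only as a limit. The expected step amounts to a step that the limit leaves unreadable from compound 2 to compound 4.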

Compound 4, concentration lethal to 50% of the cells: > 10000 nM
Compound 4 was reported as a limit (the forecaster's own chance of this, stated with the estimate: 90%); the middle value lies beyond the limit too.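

No step from compound 2 to compound 4 can be read, because both compounds stand only as limits, not as numbers: the limit of > 10000 nM in this assay, at which 2 of the 4 values shown sit.

The compounds shown leave open whether isopropyl in place of 2-methoxyethyl changes the number on the core of compound 2.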